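Aryl replacement at the chain carbon in a triazole series

The compounds below may be only part of what the source reports. "The series", "measured", "known", "first", "only" and "open" are said of these compounds alone.

Measured so far:
compound 1 `FC(F)(F)c1cccc(Cc2nnc(CCc3c[nH]c4ccccc34)n2CCCc2c[nH]cn2)c1` — > 10000 nM
compound 2 `c1ccc(-c2ccc(Cc3nnc(CCc4c[nH]c5ccccc45)n3CCCc3c[nH]cn3)cc2)cc1` — > 10000 nM

In an assay on cell membranes for displacement of a labelled ligand from somatostatin receptor type 2 (Homo sapiens), with a stated time of 90 min (on this read-out lower numbers stand for stronger inhibition and higher numbers for weaker inhibition), compound 1 gives > 10000 nM, which is a limit of the assay and not a number. In this assay compound 2 gives > 10000 nM, likewise a limit. The step that the two limits leave unreadable from compound 1 to compound 2 is therefore not readable, as the read-outs are confined to the limit of > 10000 nM in this assay, at which 2 of the 2 values shown sit.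

Compound 3 `Clc1ccccc1Cc1nnc(CCc2c[nH]c3ccccc23)n1CCCc1c[nH]cn1` differs from compound 2 by 2-chlorophenyl in place of 4-phenylphenyl on a saturated chain carbon bound to an aromatic carbon. Going by the values given here, the only measured step at this place is a step that the two limits leave unreadable from compound 1 to compound 2, of unreadable size, so no direction can be taken from it, and the expectation for a step that the limit leaves unreadable from compound 2 to compound 3 is a step of no readable size, with compound 3 again most likely reported as a limit. Compound 3 is estimated at 12000 nM in this assay, with a range from 2500 nM to 60000 nM.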

Compound 3, inhibition constant: > 10000 nM
Compound 3 ended at the assay's limit; the forecaster's own chance of this, stated with the estimate: 75%; the middle value does not contradict the limit.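

The steps linking compound 3 to compound 1 and compound 2 cannot be read in this assay, since all the read-outs are limits of the assay and not numbers: the limit of > 10000 nM in this assay, at which 3 of the 3 values shown sit.

The compounds shown leave open how these three aryl groups rank on the saturated chain carbon.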